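Lengthening the hydroxyalkyl chain on a quinone core

The source may report more compounds than this note shows. Statements on the series, on what has been measured and on what is new or still open speak of the compounds shown alone.

Measured compounds:
- compound 1, `COc1cc(CO)c(OC)c2c1C(=O)C=CC2=O`: 0.062 ug/mL
- compound 2, `CCC(O)C1=CC(=O)c2c(OC)ccc(OC)c2C1=O`: 0.516 ug/mL

In a functional assay on L1210 cells (Mus musculus) for cytotoxicity (a lower number here means that less compound is needed, a higher number that more compound is needed for the effect), compound 1 gives 0.062 ug/mL, the lowest of the two numbers. Compound 2, which carries a different hydroxyalkyl group on a differently substituted core, gives 0.516 ug/mL in this assay, a gap beyond the scatter. For the measured compounds named here, no single-point step between measured compounds exists, so nothing shows directly how a longer chain at the hydroxymethyl carbon behaves.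

Compound 3, `CCCCCC(O)c1cc(OC)c2c(c1OC)C(=O)C=CC2=O`, differs from compound 1 by pentyl in place of hydrogen on a saturated chain carbon bound to an aromatic carbon and an oxygen on a saturated carbon. Going by the values given here, because compound 1 sits at 0.062 ug/mL and no step with a comparable change is available, the expectation for compound 3 rests on that single anchor. The expected step of a 1.9-fold higher number from compound 1 to compound 3 (0.29 log units; within the scatter) is small, toward a somewhat higher number, and may not exceed the scatter. Compound 3 is estimated at 0.12 ug/mL, with a range from 0.04 ug/mL to 0.4 ug/mL.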

Compound 3, concentration for half-maximal effect: 0.066 ug/mL
For compound 3 the middle estimate is 1.8-fold (0.26 log units) above the measured one; measured number inside the range.
By their numbers in this assay, from the lowest: compounds 1 and 3 (each within the scatter of the next); then compound 2.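

In this assay, pentyl in place of hydrogen on a saturated chain carbon bound to an aromatic carbon and an oxygen on a saturated carbon gives a 1.1-fold higher number from compound 1 to compound 3 (0.03 log units; within the scatter). For the compounds shown here, this is the first direct reading at this position, and it shows that going from hydroxymethyl to 1-hydroxyhexyl on the shared core leaves a difference that cannot be told from the scatter. Nothing at hand offers a reason for this result.

As far as these compounds go, whether the same holds for a longer chain, or for an amine or a carboxylic acid in place of the pentyl, stays open. Also open, from the compounds shown here alone, is whether pentyl would give a similar reading on the differently substituted core of compound 2.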